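The compounds below may be only part of what the source reports. "The series", "measured", "known", "first", "only" and "open" are said of these compounds alone.

Compound 3 `CC1=CC[C@@H]([C@@](C)(O)CCCC(C)(C)NC(=S)N/N=C\c2ccccc2[N+](=O)[O-])CC1` belongs to a small set of three measured thiosemicarbazones that share one core and differ only in the aromatic ring at the end. In a functional assay on MCF7 cells (Homo sapiens) for cytotoxicity, read by sulforhodamine B assay (a higher number here means a weaker inhibitor of growth, a lower number a stronger inhibitor of growth), compound 3 reaches only a limit of the assay, > 100000 nM. Compound 1 `CC1=CC[C@@H]([C@@](C)(O)CCCC(C)(C)NC(=S)N/N=C\c2ccccc2)CC1`, with an unsubstituted ring, gives 28700 nM in this assay. Compound 2 `CC1=CC[C@@H]([C@@](C)(O)CCCC(C)(C)NC(=S)N/N=C\c2ccc(C)cc2)CC1` likewise stops at a limit, > 100000 nM. The two readable steps are an at least 3.4-fold higher number from compound 1 to compound 3 (0.54 log units; beyond the scatter) and an at least 3.4-fold higher number from compound 1 to compound 2 (0.54 log units; beyond the scatter), while the step that the two limits leave unreadable from compound 2 to compound 3 cannot be sized because of the limit of > 100000 nM in this assay, at which 2 of the 3 values shown sit.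

Compound 4 `CC1=CC[C@@H]([C@@](C)(O)CCCC(C)(C)NC(=S)N/N=C\c2ccccc2Cl)CC1` is now the next compound, and its change from compound 3 is chloro in place of nitro on an aromatic carbon. Among the compounds with values here, since no measured step covers a chloro group, the expectation rests on the steps from compound 1: the step from compound 3 to compound 4 is estimated at an at least 1.6-fold lower number from compound 3 to compound 4 (0.22 log units; that floor lies within the scatter), and compound 4 is expected to give 60000 nM in this assay, between 20000 nM and 150000 nM.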

Compound 4, concentration for total growth inhibition: > 100000 nM
Compound 4 was reported as a limit (the forecaster's own chance of this, stated with the estimate: 45%); at least 1.6-fold (0.22 log units) between middle value and limit.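

Chloro, the smallest of the replacements here, also weakens growth inhibition relative to the unsubstituted ring, giving an at least 3.4-fold higher number from compound 1 to compound 4 (0.54 log units; beyond the scatter). Within the data shown here, compound 1 is therefore still the only compound with a readable value in this assay, and replacing nitro with chloro does not restore one. The steps among compound 2, compound 3 and compound 4 cannot be read: the limit of > 100000 nM in this assay, at which 3 of the 4 values shown sit.

From the compounds shown here alone, how far these three compounds truly differ remains open. It is also unknown whether an amine or a carboxylic acid in place of chloro would give a readable value or match compound 1.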